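From pyridin-4-yl to benzyl: a step with little guidance

A few compounds are considered here, and "the series" means these few. Any claim that something is new, unique, unknown or untested is made for them only; others in the source may bear on it.

Measured in a functional assay on PC-3 cells (Homo sapiens) for cytotoxicity, read by WST assay, with a stated time of 72 h; on this read-out higher numbers stand for weaker inhibition and lower numbers for stronger inhibition:
Compound 1 `CCCOc1ccc(C2(c3ccc(O)cc3)C(=O)Nc3c2ccc(F)c3F)cc1`: > 1000 nM (a limit)
Compound 2 `CCCCCOc1ccc(C2(c3ccc(O)cc3)C(=O)Nc3c2ccc(F)c3F)cc1`: > 1000 nM (a limit)
Compound 3 `O=C1Nc2c(ccc(F)c2F)C1(c1ccncc1)c1ccc(O)cc1`: 110 nM

Going by the values given here, compound 3, at 110 nM, holds the only true number so far. For compound 1 and compound 2, the data show (the limit of > 1000 nM in this assay, at which 2 of the 3 values shown sit).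

The move to compound 4 `O=C1Nc2c(ccc(F)c2F)C1(Cc1ccccc1)c1ccc(O)cc1` puts benzyl in place of pyridin-4-yl on a saturated ring carbon.

Among the compounds with values here, the one measured step, a step that the two limits leave unreadable from compound 1 to compound 2, lies elsewhere in the structure, so no measured step sizes this change directly. Within the data shown here, the only hint comes from compound 1 and compound 2, which also carry a carbon-only aromatic ring on that saturated ring carbon and give no number, as the limit of > 1000 nM in this assay, at which 2 of the 3 values shown sit, shows. They differ from compound 4 in other ways too, so this is weak guidance. The expected step is a 4.5-fold higher number from compound 3 to compound 4 (0.66 log units; beyond the scatter), toward weaker inhibition. For compound 4 the estimated value is 500 nM, with an expected range of 120 nM to 2000 nM.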

Compound 4, half-maximal inhibitory concentration: > 1000 nM
Compound 4 was reported as a limit (the forecaster's own chance of this, stated with the estimate: 35%); at least 2.0-fold (0.30 log units) between middle value and limit.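

In this assay, benzyl in place of pyridin-4-yl on the saturated ring carbon gives an at least 9.0-fold higher number from compound 3 to compound 4 (0.95 log units; beyond the scatter). Going by these compounds alone, this is the first readable step at this position, and it shows that the pyridin-4-yl of compound 3 cannot be swapped for benzyl without a clear loss of inhibition, something compound 1 and compound 2 could only hint at, as they differ from compound 3 in more than one way. The value of compound 4 is itself a limit, so the step gives only a minimum size, and compound 4 joins compound 1 and compound 2 there: the limit of > 1000 nM in this assay, at which 3 of the 4 values shown sit.

The swap removes the ring nitrogen of pyridin-4-yl and adds a carbon link in benzyl at once, and the compounds shown do not tell which of the two matters. Plain phenyl or pyridin-4-ylmethyl on that ring carbon would pull the two apart.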